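A Smaller Amine at the End of the Chain

The source may report more compounds than this note shows. Statements on the series, on what has been measured and on what is new or still open speak of the compounds shown alone.

Compound 1 `c1ccc(CN(CCCCN(C[C@H]2Cc3ccccc3CN2)[C@H]2CCCc3cccnc32)Cc2ccccn2)nc1`: 664 nM in a functional assay on cells for antagonist activity at C-X-C chemokine receptor type 4 (Homo sapiens), read by fluorescence and calcium flux, with stated times of 25 min and 90 s; a higher number here means a weaker inhibitor, a lower number a stronger inhibitor
Compound 2 `c1ccc2c(c1)CN[C@@H](CN(CCCCN(Cc1ccncc1)Cc1ccncc1)[C@H]1CCCc3cccnc31)C2`: 832 nM
Compound 3 `c1ccc2c(c1)CN[C@@H](CN(CCCCNC1CCCCC1)[C@H]1CCCc3cccnc31)C2`: 75.2 nM

Compound 3 gives the lowest number of the three, and its distance from both compound 1 and compound 2 lies beyond the usual scatter, so it is the strongest inhibitor among the measured compounds. Compound 4 `CC(C)(N)CCCN(C[C@H]1Cc2ccccc2CN1)[C@H]1CCCc2cccnc21` differs from compound 3 in one place: 1-amino-1-methylethyl in place of (cyclohexylamino)methyl on a saturated chain carbon, three bonds along the chain from an amine nitrogen. Within the data shown here, no measured pair shows this kind of change, so its size is unknown. The shared core is kept, and a modest weakening in this assay is expected, with the step of a 2.0-fold higher number from compound 3 to compound 4 (0.30 log units; within the scatter) from compound 3 to compound 4 estimated as small. Compound 4 is expected to give about 150 nM, within a range from 40 nM to 600 nM.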

Compound 4, half-maximal inhibitory concentration: 24.6 nM
Beside the measured number, compound 4's estimate is 6.1-fold (0.79 log units) above it; the measured number lies below the stated range.
By their numbers in this assay, from the lowest: compound 4; then compound 3; then compounds 1 and 2 (each within the scatter of the next).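

In this assay, this position does not need the six-membered ring: 1-amino-1-methylethyl in place of (cyclohexylamino)methyl gives a 3.1-fold lower number from compound 3 to compound 4 (0.49 log units; beyond the scatter), a step beyond the scatter. Among these compounds, the group with fewer heavy atoms and no ring therefore does better here, which the earlier compounds could not show. Nothing shown here gives a reason for this gain.

From the compounds shown here alone, the step removes the ring and adds the two methyl groups in one change, so their separate contributions remain open. A plain 4-aminobutyl group at this position would help to separate them.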